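Series notes: from compound 1 to compound 4

The source may report more compounds than this note shows. Statements on the series, on what has been measured and on what is new or still open speak of the compounds shown alone.

Compound 1 `CCc1ccc(-c2ccc(NC3=CC(=O)c4ncncc4C3=O)cc2)cc1`: 3100 nM
Compound 2 `O=C1C=CC(=O)c2ncncc21`: 19400 nM
Compound 3 `O=C1C(NCc2ccc(F)cc2)=CC(=O)c2ncncc21`: 1400 nM

In a functional assay on BXPC-3 cells (Homo sapiens) for cytotoxicity, read by MTT assay, with a stated time of 72 h (a higher number here means a weaker inhibitor, a lower number a stronger inhibitor), compound 1 gives 3100 nM, the second highest of the three numbers. Compound 3 sits nearest, with a lower number beyond the scatter; compound 2, the shared core alone, gives the highest number and lies furthest from compound 1. Compound 4 `O=C1C(Nc2ccc(CO)cc2)=CC(=O)c2ncncc21` has not been measured. Against compound 1 it differs thus: hydroxymethyl in place of 4-ethylphenyl on an aromatic carbon. Within the data shown here, no measured pair covers this change, so its step cannot be read from the data; the expectation is no step beyond the scatter, estimated as a 1.1-fold higher number from compound 1 to compound 4 (0.05 log units; within the scatter). Compound 4 is expected to give about 3500 nM, in the range 1200 nM to 10000 nM.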

Compound 4, half-maximal inhibitory concentration: 5700 nM
Compound 4: the middle estimate sits 1.6-fold (0.21 log units) below what was measured; low and high end bracket the measured number.
By their numbers in this assay, from the lowest: compound 3; then compounds 1 and 4 (each within the scatter of the next); then compound 2.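

Hydroxymethyl in place of 4-ethylphenyl gives a 1.8-fold higher number from compound 1 to compound 4 (0.26 log units; within the scatter) in this assay. On this aromatic carbon, then, a group with no ring and with a hydrogen-bond donor and acceptor stands level with the much larger 4-ethylphenyl, whose aromatic ring is not needed to hold the number within the scatter. No measurement is at hand that would explain this step.

From the compounds shown here alone, whether an amine, a carboxylic acid or a longer chain on this carbon would also stay within the scatter remains open. Going by these compounds, whether the hydroxyl of hydroxymethyl contributes at all also remains open, and a plain methyl would address that.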